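Replacing Cyclopropyl on the Amide-Type Nitrogen of Compound 2

The compounds below may be only part of what the source reports. "The series", "measured", "known", "first", "only" and "open" are said of these compounds alone.

Compound 1 `COc1ncc(-c2ccc3nc(NC(=O)NCCN4CCCC4)nn3c2)cc1NS(=O)(=O)c1ccc(F)cc1`: 1120 nM
Compound 2 `COc1ncc(-c2ccc3nc(NC(=O)NC4CC4)nn3c2)cc1NS(=O)(=O)c1ccc(F)cc1`: 540 nM
Compound 3 `CCN(CC)CCNC(=O)Nc1nc2ccc(-c3cnc(OC)c(NS(=O)(=O)c4ccc(F)cc4F)c3)cn2n1`: 1060 nM

In a functional assay on U-87MG ATCC cells for cytotoxicity against U-87 MG (Homo sapiens), read by MTT assay, with a stated time of 72 h (on this read-out lower numbers stand for stronger inhibition and higher numbers for weaker inhibition), compound 2 shows the lowest of the three numbers, though compound 3 sits within the scatter of it and only compound 1 lies beyond. Compound 4 `COc1ncc(-c2ccc3nc(NC(=O)NCC(=O)N4CCCCC4)nn3c2)cc1NS(=O)(=O)c1ccc(F)cc1` differs from compound 2 by ((piperidin-1-yl)carbonyl)methyl in place of cyclopropyl on an amide-type nitrogen. Among the measured compounds shown here, the one measured step at this position is a 2.1-fold lower number from compound 1 to compound 2 (0.32 log units; beyond the scatter), where a small ring replaced a longer, larger group and gave the lower number. Compound 4 moves the other way, back to a larger group on that nitrogen, so a step of similar size in the opposite direction is expected, a 1.9-fold higher number from compound 2 to compound 4 (0.27 log units; within the scatter). Compound 4 is therefore estimated at 1000 nM, with a range from 450 nM to 2500 nM.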

Compound 4, half-maximal inhibitory concentration: 740 nM
Beside the measured number, compound 4's estimate is 1.4-fold (0.13 log units) above it; the measured number falls inside the stated range.
By their numbers in this assay, from the lowest: compounds 2, 4, 3 and 1 (each within the scatter of the next, the first and the last beyond it).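

In this assay, putting ((piperidin-1-yl)carbonyl)methyl in place of cyclopropyl on the amide-type nitrogen gives a 1.4-fold higher number from compound 2 to compound 4 (0.14 log units; within the scatter) and so no readable change, which shows that this position tolerates a group with a six-membered ring and a carbonyl. The step of (piperidin-1-yl)carbonyl in place of (pyrrolidin-1-yl)methyl, a 1.5-fold lower number from compound 1 to compound 4 (0.18 log units; within the scatter), likewise cannot separate those two groups. No supporting measurement bears on why these numbers fall as they do. From the compounds shown here alone, whether a carboxylic acid or a longer chain on this nitrogen would move the number beyond the scatter remains open.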